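This account rests on a few compounds, and the source may have more. Where it says the series, first, only, none or still open, it means among the compounds named here.

Compound 1 `O=C(CN1CCCCC1)Nc1ccc2ncnc(Nc3ccc(Cl)cc3)c2c1` pairs a 4-chlorophenylamino quinazoline core with a piperidin-1-yl acetamide. In a functional assay on HepG2 cells (Homo sapiens) for antiproliferative activity, read by MTT assay, with a stated time of 48 h (a higher number here means a weaker inhibitor, a lower number a stronger inhibitor), compound 1 gives 16000 nM. Compound 2 `CN1CCN(CC(=O)Nc2ccc3ncnc(Nc4ccc(Cl)cc4)c3c2)CC1` differs from compound 1 only in the side chain: 4-methylpiperazin-1-yl in place of piperidin-1-yl on a saturated chain carbon bound to a carbonyl carbon. The value of compound 2 in this assay is a limit of the assay rather than a number, > 100000 nM. This step is an at least 6.2-fold higher number from compound 1 to compound 2 (0.79 log units; beyond the scatter). Compound 3 `O=C(CN1CCCCC1)Nc1ccc2ncnc(Nc3ccc(Br)cc3)c2c1` keeps the piperidin-1-yl acetamide and alters the aryl ring instead: bromo in place of chloro on an aromatic carbon. For compound 3 the read-out in this assay is again a limit and not a number, > 100000 nM. That step is an at least 6.2-fold higher number from compound 1 to compound 3 (0.79 log units; beyond the scatter). Two of the three values obtained so far sit at the limit of > 100000 nM in this assay, at which 2 of the 3 values shown sit, so the measurable range is already exhausted in those two cases.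

Compound 4 `CN1CCN(CC(=O)Nc2ccc3ncnc(Nc4ccc(Br)cc4)c3c2)CC1` is not yet measured. It stands to compound 3 as compound 2 stands to compound 1: 4-methylpiperazin-1-yl in place of piperidin-1-yl on a saturated chain carbon bound to a carbonyl carbon. The place of the change is the same in both pairs word for word, so it is the same change. Because the step of an at least 6.2-fold higher number from compound 1 to compound 2 (0.79 log units; beyond the scatter) was at least modest and ran toward weaker inhibition, and because compound 3 already sits at a limit with > 100000 nM, the expected step is a step that the limit leaves unreadable from compound 3 to compound 4. Compound 4 is therefore expected to give about 200000 nM, estimated between 100000 nM and 500000 nM, most likely reported only as a limit.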

Compound 4, half-maximal inhibitory concentration: > 100000 nM
Compound 4: no number, only a limit; the forecaster's own chance of this, stated with the estimate: 85%; the middle value does not contradict the limit.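

The steps from compound 3 to compound 4 and from compound 2 to compound 4 cannot be read, as compound 2, compound 3 and compound 4 all give the same limit rather than a number: the limit of > 100000 nM in this assay, at which 3 of the 4 values shown sit. The compounds shown leave open how these three compare with one another, and so whether 4-methylpiperazin-1-yl in place of piperidin-1-yl has any effect on the bromo side of the series.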